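The source may report more compounds than this note shows. Statements on the series, on what has been measured and on what is new or still open speak of the compounds shown alone.

In a functional assay on the whole organism with Rattus norvegicus as the target (on this read-out higher numbers stand for an effect only at larger amounts of compound and lower numbers for an effect already at smaller amounts), compound 1 `CCc1c(OC)nc2nc(-c3nnco3)cn2c1C` gives > 50 mg/kg, which is a limit of the assay rather than a measured number. Compound 2 `CCCc1nnc(-c2cn3c(C)c(CC)c(OC)nc3n2)o1` gives 50 mg/kg in this assay. Compound 3 `CCc1c(OC)nc2nc(-c3nnc(-c4ccccc4)o3)cn2c1C` gives > 50 mg/kg, again a limit of the assay and not a number. Two of the three values shown sit at the limit of > 50 mg/kg in this assay, at which 2 of the 3 values shown sit, so compound 1 stands at the limit together with compound 3, and its relation to compound 2 is left open.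

Compound 4 `CCc1c(OC)nc2nc(-c3nc(C)cs3)cn2c1C` differs from compound 1 in one place: 4-methyl-1,3-thiazol-2-yl in place of 1,3,4-oxadiazol-2-yl on an aromatic carbon. The steps measured so far all alter the substituent on the 1,3,4-oxadiazol-2-yl ring. The change from compound 1 to compound 2 gave a number no higher from compound 1 to compound 2 (the limit leaves the size open), from compound 1 to compound 3 a step that the two limits leave unreadable from compound 1 to compound 3, and from compound 2 to compound 3 a number no lower from compound 2 to compound 3 (the limit leaves the size open). For the measured compounds named here, none of these exchanges the ring itself, so no measured step bears directly on the change to compound 4, and their sizes are not readable in any case. With nothing to point either way, compound 4 is expected to remain near the values already seen, a step of about a number no higher from compound 1 to compound 4 (the limit leaves the size open). The estimate for compound 4 is therefore 50 mg/kg, with a range from 20 mg/kg to 100 mg/kg.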

Compound 4, minimum effective dose: > 50 mg/kg
Compound 4 gave a limit, no number; the forecaster's own chance of this, stated with the estimate: 60%; the middle value lies on the limit itself.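

Compound 1 and compound 4 both sit at a limit of the assay rather than at a number, so no size can be read for the step between them: the limit of > 50 mg/kg in this assay, at which 3 of the 4 values shown sit.

The compounds shown leave open whether 4-methyl-1,3-thiazol-2-yl in place of 1,3,4-oxadiazol-2-yl changes the dose needed in this assay, and by how much.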